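Swapping piperidin-1-yl for 4-propylpiperazin-1-yl

This account rests on a few compounds, and the source may have more. Where it says the series, first, only, none or still open, it means among the compounds named here.

In a toxicity assay on L02 cells (Homo sapiens) for cytotoxicity, read by MTT assay, with a stated time of 72 h (on this read-out lower numbers stand for stronger inhibition and higher numbers for weaker inhibition), compound 3 (`O=C1c2c[n+]([O-])c3ccccc3c2C(=O)c2c1c1ccccc1n2CCCCN1CCCCC1`) gives 610 nM and stands second highest of three numbers. Compound 1 (`CN(C)CCCCCn1c2c(c3ccccc31)C(=O)c1c[n+]([O-])c3ccccc3c1C2=O`) lies lower with 240 nM and compound 2 (`CCCCN1CCN(CCCCn2c3c(c4ccccc42)C(=O)c2c[n+]([O-])c4ccccc4c2C3=O)CC1`) lies higher with 5690 nM on the same scale. Compound 4 (`CCCN1CCN(CCCCn2c3c(c4ccccc42)C(=O)c2c[n+]([O-])c4ccccc4c2C3=O)CC1`) comes from compound 3 by a single change (4-propylpiperazin-1-yl in place of piperidin-1-yl on a saturated chain carbon, four bonds along the chain from an aromatic nitrogen) that puts 4-propylpiperazin-1-yl in place of piperidin-1-yl. The closest guide is the modest step of a 9.3-fold lower number from compound 2 to compound 3 (0.97 log units; beyond the scatter) in which 4-butylpiperazin-1-yl gave way to piperidin-1-yl. The large step of a 24-fold higher number from compound 1 to compound 2 (1.37 log units; beyond the scatter) also brought in 4-butylpiperazin-1-yl and also raised the number. Read in reverse, the modest step points upward, so a step of a 6.6-fold higher number from compound 3 to compound 4 (0.82 log units; beyond the scatter) is expected, beyond the scatter and toward weaker inhibition. In this assay the estimated value for compound 4 is 4000 nM with 1500 nM to 10000 nM as the expected range.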

Compound 4, half-maximal inhibitory concentration: 6830 nM
Beside the measured number, compound 4's estimate is 1.7-fold (0.23 log units) below it, and the stated range covers the measured number.
By their numbers in this assay, from the lowest: compound 1; then compound 3; then compounds 2 and 4 (each within the scatter of the next).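

In this assay the rise first seen with 4-butylpiperazin-1-yl returns with 4-propylpiperazin-1-yl, both in an 11-fold higher number from compound 3 to compound 4 (1.05 log units; beyond the scatter) and in a 28-fold higher number from compound 1 to compound 4 (1.45 log units; beyond the scatter) at this saturated chain carbon. The step of a 1.2-fold higher number from compound 2 to compound 4 (0.08 log units; within the scatter) shows that shortening the butyl to propyl on that ring makes no real difference here. Nothing measured here gives a reason for the rise. Still open, on these data alone, is whether the second ring nitrogen or the alkyl chain on it drives the rise, which an unsubstituted piperazin-1-yl or a morpholin-4-yl could help separate.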